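The source may report more compounds than this note shows. Statements on the series, on what has been measured and on what is new or still open speak of the compounds shown alone.

Of the compounds shown here, three sharing one core have so far been tested in an ADME assay on Huh-7 cells (Homo sapiens) for cytotoxicity, with a stated time of 72 h; a higher number here means that more compound is tolerated, a lower number that less compound is tolerated. Compound 1 (`COC(=O)n1c(=O)c(C)cn([C@@H]2O[C@H](CO[Si](C)(C)C(C)(C)C)[C@@]3(OS(=O)(=O)C=C3N)[C@H]2O[Si](C)(C)C(C)(C)C)c1=O`) gives > 100000 nM here, which is a limit of the assay and not a number. Compound 2 (`Cc1cn([C@@H]2O[C@H](CO[Si](C)(C)C(C)(C)C)[C@@]3(OS(=O)(=O)C=C3N)[C@H]2O[Si](C)(C)C(C)(C)C)c(=O)n(C(=O)C2CC2)c1=O`) gives > 100000 nM, again only a limit. Compound 3 (`COC(=O)CCCC(=O)n1c(=O)c(C)cn([C@@H]2O[C@H](CO[Si](C)(C)C(C)(C)C)[C@@]3(OS(=O)(=O)C=C3N)[C@H]2O[Si](C)(C)C(C)(C)C)c1=O`) gives > 100000 nM, so it too stands at a limit. The whole set rests on the limit of > 100000 nM in this assay, at which 3 of the 3 values shown sit, and no order among the compounds can be read.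

Compound 4 (`Cc1cn([C@@H]2O[C@H](CO[Si](C)(C)C(C)(C)C)[C@@]3(OS(=O)(=O)C=C3N)[C@H]2O[Si](C)(C)C(C)(C)C)c(=O)n(C(=O)CCCC(=O)OCc2ccccc2)c1=O`) differs from compound 3 by one change (phenyl in place of hydrogen on a saturated chain carbon bound to an oxygen next to a carbonyl group): phenyl in place of hydrogen on a saturated chain carbon bound to an oxygen next to a carbonyl group, so that methoxycarbonyl becomes benzyloxycarbonyl. The nearest guides are the swaps on a carbonyl carbon (a step that the two limits leave unreadable from compound 1 to compound 2, a step that the two limits leave unreadable from compound 1 to compound 3 and a step that the two limits leave unreadable from compound 2 to compound 3), none of which has a readable size and none of which adds phenyl. They give only weak support, but every one of them stays at the same limit. The expected step (a number no higher from compound 3 to compound 4 (the limit leaves the size open)) is therefore none beyond the scatter, in either direction. For compound 4 the estimate, expected to fall between 50000 nM and 200000 nM, is 100000 nM, quite possibly reported again only as a limit.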

Compound 4, half-maximal cytotoxic concentration: > 100000 nM
Compound 4: no number, only a limit (the forecaster's own chance of this, stated with the estimate: 80%); the middle value lies on the limit itself.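

Compound 4, like compound 3, gives only a limit in this assay, so the step between compound 3 and compound 4 cannot be read. The compounds shown leave open how they rank against one another and whether any change on the shared core would give a measurable value, as every result rests on one boundary: the limit of > 100000 nM in this assay, at which 4 of the 4 values shown sit.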